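Working notes: from compound 2 to compound 3

This account rests on a few compounds, and the source may have more. Where it says the series, first, only, none or still open, it means among the compounds named here.

Two compounds of the series carry a value in a functional assay on KYSE-410 cells (Homo sapiens) for antiproliferative activity, read by MTT assay, with a stated time of 72 h (on this read-out lower numbers stand for stronger inhibition and higher numbers for weaker inhibition), so far. Compound 1 `COc1ccccc1NC(=O)c1cc(=O)[nH]c2cc(Br)ccc12` returns only a limit there, > 20000 nM. Compound 2 `O=C(Nc1cccc(F)c1)c1cc(=O)[nH]c2cc(-c3ccccc3F)ccc12` likewise returns only a limit in this assay, > 20000 nM. Within the data shown here, the whole of the evidence is the limit of > 20000 nM in this assay, at which 2 of the 2 values shown sit, so no step between measured compounds can be drawn, and the numbers give no order between compound 1 and compound 2. Compound 3 `O=C(Nc1cccc(F)c1)c1cc(=O)[nH]c2cc(-c3ccc(F)c(CO)c3)ccc12` is the next compound to be measured: 4-fluoro-3-(hydroxymethyl)phenyl in place of 2-fluorophenyl on an aromatic carbon. Among the measured compounds shown here, with no measured step to lean on, the change from compound 2 to compound 3 is expected to move this assay only modestly, if at all, and a result that again sits at the limit is quite possible. Compound 3 is therefore estimated at 12000 nM, within 3000 nM to 40000 nM. The expected step is an at least 1.6-fold lower number from compound 2 to compound 3 (0.22 log units; that floor lies within the scatter).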

Compound 3, half-maximal inhibitory concentration: > 20000 nM
Compound 3: a limit, no number; the forecaster's own chance of this, stated with the estimate: 60%; middle value at least 1.6-fold (0.22 log units) from the limit.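

Compound 2 and compound 3 both return only a limit in this assay, so no step can be read between them. The compounds shown leave open which structure, if any, would give a measured number rather than a limit: the limit of > 20000 nM in this assay, at which 3 of the 3 values shown sit.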